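Adding a chloro group to the benzyl arm on two cores

The source may report more compounds than this note shows. Statements on the series, on what has been measured and on what is new or still open speak of the compounds shown alone.

Compound 1 `O=[N+]([O-])c1cc(C(F)(F)F)cc([N+](=O)[O-])c1Oc1ccc(Cl)cc1/C=N\OCc1ccccc1Cl` carries one chloro group on its benzyl arm. In a functional assay on A549 cells (Homo sapiens) for antiproliferative activity, read by MTT assay, with a stated time of 48 h (on this read-out lower numbers stand for stronger inhibition and higher numbers for weaker inhibition), compound 1 gives 5030 nM. Compound 2 `O=[N+]([O-])c1cc(C(F)(F)F)cc([N+](=O)[O-])c1Oc1ccc(Cl)cc1/C=N\OCc1ccc(Cl)cc1Cl` differs from it by chloro in place of hydrogen on an aromatic carbon. In this assay compound 2 gives 3440 nM, and the step of a 1.5-fold lower number from compound 1 to compound 2 (0.17 log units; within the scatter) is therefore a small one. Compound 3 `O=[N+]([O-])c1cc(C(F)(F)F)cc([N+](=O)[O-])c1Oc1c(Cl)cc(Cl)cc1/C=N/OCc1ccccc1Cl` is built on a differently substituted core; the difference between the core of compound 1 and the core of compound 3 is not broken down here. In this assay compound 3 gives 2160 nM; its gap to compound 2 lies within the scatter, while its gap to compound 1 lies beyond it.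

Compound 4 `O=[N+]([O-])c1cc(C(F)(F)F)cc([N+](=O)[O-])c1Oc1c(Cl)cc(Cl)cc1/C=N/OCc1ccc(Cl)cc1Cl` has not yet been measured. It differs from compound 3 by chloro in place of hydrogen on an aromatic carbon. This is the same change that turns compound 1 into compound 2, now made on the other core, and the surroundings of the place are described in the same words. Because that earlier step a 1.5-fold lower number from compound 1 to compound 2 (0.17 log units; within the scatter) stayed within the scatter, the change is expected to move the number only a little here as well. The expected step of a 1.4-fold lower number from compound 3 to compound 4 (0.13 log units; within the scatter) is estimated to be of that small size. In this assay compound 4 is expected to give about 1600 nM, most likely between 800 nM and 3500 nM.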

Compound 4, half-maximal inhibitory concentration: 1420 nM
Beside the measured number, compound 4's estimate is 1.1-fold (0.05 log units) above it; the measured number falls inside the stated range.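

In this assay, turning the 2-chlorobenzyl arm into a 2,4-dichlorobenzyl arm on the second core gives a 1.5-fold lower number from compound 3 to compound 4 (0.18 log units; within the scatter), so the step stays within the usual scatter of repeated measurements. Set beside the earlier step, the same change is of matching small size on both cores, and the two steps cannot be told apart: the same change on two cores in this assay, a 1.5-fold lower number (0.17 log units; within the scatter) from compound 1 to compound 2 and a 1.5-fold lower number (0.18 log units; within the scatter) from compound 3 to compound 4, 1.0-fold (0.02 log units) apart, within the scatter of two such steps. This shows that, on these two cores, the small size of the step carried over from one core to the other, but each step on its own lies within the scatter, so the pair does not show that the added chloro group has any real effect on either core, and two cores are too few to set a rule for the whole series.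

The compounds shown carry only hydrogen or chloro at this place on the benzyl arm, so it remains open whether another group there, such as a methoxy group, a nitrile or an amine, would give a step beyond the scatter. Going by these compounds, it is also open whether the step would stay this small on a third core or in another cell line.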